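A few compounds are considered here, and "the series" means these few. Any claim that something is new, unique, unknown or untested is made for them only; others in the source may bear on it.

Compound 2 `CC#CCC(C)[C@H](O)/C=C/[C@H]1[C@H](O)C[C@]2(C#CCCCO)C/C(=C/CCCC(=O)O)C[C@H]12` stands lowest of the two numbers in a functional assay for inhibition, with Homo sapiens as the target (on this read-out higher numbers stand for weaker inhibition and lower numbers for stronger inhibition), where compound 2 gives 200 nM; the nearest is compound 1 `CC#CCC(C)[C@H](O)/C=C/[C@H]1[C@H](O)C[C@]2(CCCCCO)C/C(=C/CCCC(=O)O)C[C@H]12`, which in this assay gives 11000 nM. Among the compounds with values here, the only measured step, a 55-fold lower number from compound 1 to compound 2 (1.74 log units; beyond the scatter), concerns another part of the shared core and does not touch the chain end. Compound 3 `CC#CCC(C)[C@H](O)/C=C/[C@H]1[C@H](O)C[C@]2(C#CCCCN=[N+]=[N-])C/C(=C/CCCC(=O)O)C[C@H]12` differs from compound 2 by azido in place of hydroxy on a saturated chain carbon, three bonds along the chain from a triple-bonded carbon. Within the data shown here, no measured step bears on this change, so in this assay no step beyond the scatter is expected, in either direction. Compound 3 is therefore estimated at 250 nM, with a range of 80 nM to 800 nM. The expected step is a 1.3-fold higher number from compound 2 to compound 3 (0.10 log units; within the scatter).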

Compound 3, half-maximal inhibitory concentration: 850 nM
Estimate against measurement, compound 3: 3.4-fold (0.53 log units) below, and the stated range ends below it.
By their numbers in this assay, from the lowest: compound 2; then compound 3; then compound 1.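

With a 4.3-fold higher number from compound 2 to compound 3 (0.63 log units; beyond the scatter) in this assay, the chain end is shown to matter: azido does not stand in for hydroxy at this saturated chain carbon without a loss of inhibition. The pentynyl chain still keeps its advantage over the saturated chain with azido at its end, with a 13-fold lower number from compound 1 to compound 3 (1.11 log units; beyond the scatter) on the same read-out. No available evidence explains either step.

Open, from the compounds shown here alone, is whether an amine or a carboxylic acid at the chain end would hold the level of compound 2. Going by these compounds, a longer chain carrying hydroxy also remains untested here.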